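Pyrrolidinone amidine series: hydroxy on the benzylamine ring

This account rests on a few compounds, and the source may have more. Where it says the series, first, only, none or still open, it means among the compounds named here.

Measured compounds
compound 1, `COc1ccc(CN2C(=O)CC[C@H]2C(=N)NCc2ccc(O)cc2)cc1`: 26.6%
compound 2, `Cc1ccc(CN2C(=O)CC[C@H]2C(=N)NCc2ccccc2)cc1`: 24.8%

Both values come from a functional assay on SH-SY5Y cells (Homo sapiens) for cytotoxicity, read by MTT assay, with stated times of 8 h, 30 min and 12 h, tested at 5 uM; on this read-out higher numbers stand for a stronger effect at the one concentration tested and lower numbers for a weaker effect. Compound 2 stands at the lower of the two numbers, with compound 1 the nearest at a number only slightly higher, a gap that lies within the scatter; the two compounds therefore cannot be told apart on this read-out, and neither counts as the stronger.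

Compound 3, `Cc1ccc(CN2C(=O)CC[C@H]2C(=N)NCc2ccc(O)cc2)cc1`, is not yet measured. It differs from compound 2 in one place:

hydroxy in place of hydrogen on an aromatic carbon

Within the data shown here, no step between measured compounds isolates this change, since compound 1 carries it together with a second difference on the other benzyl group. Given that compound 1 and compound 2 sit within the scatter of each other, the step is expected to be none beyond the scatter, a number 1.2 percentage points higher from compound 2 to compound 3 (within the scatter). Compound 3 is thus estimated at 26%, in the range 15% to 37%.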

Compound 3, a percentage reported as activity, at one concentration (the size of the read-out at that concentration, not a potency): 23.8%
Beside the measured number, compound 3's estimate is 2.2 percentage points above it; the measured number falls inside the stated range.
By their numbers in this assay, from the lowest: compounds 3, 2 and 1 (each within the scatter of the next).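

In this assay the isolated change, phenyl to 4-hydroxyphenyl on the benzylamine ring, gives a number 1 percentage points lower from compound 2 to compound 3 (within the scatter), so hydroxy and hydrogen at this position cannot be told apart on this read-out. Compound 3 also provides a single-place comparison on the other benzyl group, where methyl in place of methoxy gives a number 2.8 percentage points lower from compound 1 to compound 3 (within the scatter), so neither change separates the compounds compared. No measurement bearing on a cause of these readings is available.

From the compounds shown here alone, whether an amine or a carboxylic acid at the position of the hydroxy, or a longer chain in place of the methyl, would separate from these three compounds remains open. Going by these compounds, all readings rest on one concentration, so whether these compounds differ at other concentrations also remains open.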